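This account rests on a few compounds, and the source may have more. Where it says the series, first, only, none or still open, it means among the compounds named here.

Measured compounds:
compound 1 `C=CCN1CCc2ccccc2C1c1ccccc1` with 1300 nM
compound 2 `Clc1ccc(C2NCCc3ccccc32)cc1` with 3400 nM
compound 3 `c1ccc2c(c1)CCNC2c1ccc2ccccc2c1` with 10000 nM

In an assay on isolated protein for binding affinity to Sigma non-opioid intracellular receptor 1 (Rattus norvegicus) (a higher number here means a weaker inhibitor, a lower number a stronger inhibitor), compound 3 gives 10000 nM, the highest of the three numbers. Its nearest neighbour is compound 2, which in this assay gives 3400 nM, a gap that lies beyond the scatter. Furthest from it stands compound 1, which gives 1300 nM in this assay, again beyond the scatter. Compound 1 is the only one of the three that carries an allyl on the ring nitrogen, and it has the lowest number.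

Compound 4 `C=CCN1CCc2ccccc2C1c1ccc2ccccc2c1` has not yet been measured. It differs from compound 3 in one place: allyl in place of hydrogen on an amine nitrogen in a ring. Among the measured compounds shown here, no measured pair shows this same change on the shared core, so its size cannot be read off directly. Given that compound 1, the allyl-bearing compound, gives 1300 nM, a step toward a lower number is expected for compound 4, of a size somewhat beyond the scatter, a 2.5-fold lower number from compound 3 to compound 4 (0.40 log units; beyond the scatter). Compound 4 is therefore estimated to give 4000 nM in this assay, within a range from 1500 nM to 12000 nM.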

Compound 4, half-maximal inhibitory concentration: 11000 nM
Estimate against measurement, compound 4: 2.8-fold (0.44 log units) below; the measured number falls inside the stated range.
By their numbers in this assay, from the lowest: compound 1; then compound 2; then compounds 3 and 4 (each within the scatter of the next).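

In this assay, putting allyl in place of hydrogen on this amine nitrogen in a ring gives a 1.1-fold higher number from compound 3 to compound 4 (0.04 log units; within the scatter) and so leaves the number unchanged on this core. The earlier impression that allyl goes with a low number therefore does not hold across the set: compound 1 carries an allyl and gives 1300 nM in this assay, but compound 4 also carries one and gives 11000 nM in the same assay. The data offer no explanation for why the change has no effect here.

On these data alone, it remains open whether the same change would also leave the number unchanged on the core of compound 1. As far as these compounds go, it is equally open whether a methyl, a propyl or a benzyl on this nitrogen would behave as the allyl does.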